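The source may hold more compounds than are shown below. What is called first, only, known or untested is meant among the compounds shown, and "the series" means these compounds.

In a functional assay on the whole organism with Canis familiaris (Canis lupus familiaris) as the target (on this read-out lower numbers stand for an effect already at smaller amounts and higher numbers for an effect only at larger amounts of compound), compound 1 (`Cc1ccccc1-c1nc2cc[nH]cc-2n1`) gives 2.2 mg/kg and compound 2 (`COc1ccc(-c2nc3cc[nH]cc-3n2)cc1`) gives 1.7 mg/kg, while compound 3 (`COc1ccc(-c2nc3cc[nH]cc-3n2)c(OC)c1`) gives 0.3 mg/kg as the lowest number of the three. Compound 4 (`COc1cc(OS(C)(=O)=O)ccc1-c1nc2cc[nH]cc-2n1`) differs from compound 3 by methylsulfonyl in place of methyl on an oxygen on an aromatic ring in that methylsulfonyl stands in place of methyl on an oxygen on an aromatic ring. Going by the values given here, the only measured step is a 5.7-fold lower number from compound 2 to compound 3 (0.75 log units; beyond the scatter) for methoxy in place of hydrogen on an aromatic carbon, and no measured pair carries the present swap. With so little to go on, a modest rise in the number is expected in this assay rather than a fall. The expected step is a 1.7-fold higher number from compound 3 to compound 4 (0.22 log units; within the scatter) by this estimate. For compound 4 the estimated value is 0.5 mg/kg with an expected range of 0.15 mg/kg to 1.6 mg/kg in this read-out.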

Compound 4, dose for half-maximal effect: 0.006 mg/kg
Compound 4: middle estimate off by 83-fold (1.92 log units), on the high side, and the stated range ends above it.
By their numbers in this assay, from the lowest: compound 4; then compound 3; then compounds 2 and 1 (each within the scatter of the next).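

In this assay, replacing methyl with methylsulfonyl on this oxygen gives a 50-fold lower number from compound 3 to compound 4 (1.70 log units; beyond the scatter), so the group carried by this oxygen can shift the dose strongly. Going by these compounds alone, the earlier compounds did not vary this oxygen; their one measured step, a 5.7-fold lower number from compound 2 to compound 3 (0.75 log units; beyond the scatter), came from a methoxy in place of hydrogen on an aromatic carbon. Nothing shown here explains the size of the new step. The compounds shown leave open whether the sulfonyl unit itself matters, as an acetyl on this oxygen could test. They also leave open how a longer chain such as ethylsulfonyl would compare.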